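Exchanging a carbocyclic ether for an open ether chain

The source may hold more compounds than are shown below. What is called first, only, known or untested is meant among the compounds shown, and "the series" means these compounds.

Of the compounds shown here, three sharing one core have been measured in an assay on cells with melanin-concentrating hormone receptor 1 (Homo sapiens) as the target, read by radioligand binding; a lower number here means a stronger inhibitor, a higher number a weaker inhibitor. Compound 1, `CC1CCC(Oc2cccc3ccc(N)nc23)C1`, gives 823 nM in this assay, which places it second highest of the three numbers. Compound 2, `CC1CC1COc1cccc2ccc(N)nc12`, gives 1640 nM, and compound 3, `Nc1ccc2cccc(OCC3CCC3)c2n1`, gives 432 nM. The step of a 2.0-fold higher number from compound 1 to compound 2 (0.30 log units; within the scatter) and the step of a 1.9-fold lower number from compound 1 to compound 3 (0.28 log units; within the scatter) both stay within the scatter, while a 3.8-fold lower number from compound 2 to compound 3 (0.58 log units; beyond the scatter) is a modest change beyond it.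

Compound 4, `CC(C)OCCOc1cccc2ccc(N)nc12`, has not yet been measured in this assay. It differs from compound 1 in one place: 2-isopropoxyethyl in place of 3-methylcyclopentyl on an oxygen on an aromatic ring. For the measured compounds named here, none of the measured steps exchanges a ring on this oxygen for an open chain, so the two within-scatter steps from compound 1 give only a loose guide, suggesting that small alterations of this group move the number little. Going by the values given here, with no direct precedent for a chain bearing an oxygen, the expected step of a 1.8-fold higher number from compound 1 to compound 4 (0.26 log units; within the scatter) is drawn wide. Compound 4 is therefore estimated at 1500 nM in this assay, with a range from 450 nM to 5000 nM.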

Compound 4, half-maximal inhibitory concentration: > 2000 nM
Compound 4: no number, only a limit (the forecaster's own chance of this, stated with the estimate: 5%); at least 1.3-fold (0.12 log units) between middle value and limit.
By their numbers in this assay, from the lowest: compounds 3, 1 and 2 (each within the scatter of the next, the first and the last beyond it). At a limit, above all of these: compound 4.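

In this assay, compound 4 gives > 2000 nM, which is a limit of the assay and not a number. Although 2-isopropoxyethyl and 3-methylcyclopentyl have 6 heavy atoms each, exchanging the ring for this open chain gives an at least 2.4-fold higher number from compound 1 to compound 4 (0.38 log units; beyond the scatter), the first step from that ring to go beyond the scatter, and a comparison with the cyclobutylmethyl ether gives an at least 4.6-fold higher number from compound 3 to compound 4 (0.66 log units; beyond the scatter). The third comparison is less sharp, an at least 1.2-fold higher number from compound 2 to compound 4 (0.08 log units; that floor lies within the scatter), so this floor does not separate those two compounds.

From the compounds shown here alone, how far the true number lies beyond the limit remains open, as does whether the weaker result follows from losing the ring or from the oxygen in the chain. An all-carbon hexyl chain on this oxygen, or a chain carrying an amine in place of that oxygen, would help to tell these apart.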